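Series notes: exchanging the aryl substituent of compound 1

A few compounds are considered here, and "the series" means these few. Any claim that something is new, unique, unknown or untested is made for them only; others in the source may bear on it.

Two compounds of this series carry a measured number in a functional assay (Homo sapiens); on this read-out higher numbers stand for weaker inhibition and lower numbers for stronger inhibition. Compound 1 `Nc1nc2ccnc(-c3cccc(C(Cl)Cl)c3)n2n1` gives 1000 nM in this assay, the lower of the two numbers. Compound 2 `CC(=O)Nc1nc2c(C)cnc(-c3cccc(NS(=O)(=O)c4ccc(C)cc4)c3)n2n1` differs from compound 1 at several places at once; in this assay compound 2 gives 51800 nM, a much higher number that lies beyond the scatter. Within the data shown here, as no single-point step connects the two, only the pair of values itself is on record.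

Compound 3 `CN(C)C(=O)c1cccc(-c2nccc3nc(N)nn23)c1` is the next compound and has not yet been measured in this assay. It differs from compound 1 in one place: dimethylcarbamoyl in place of dichloromethyl on an aromatic carbon. Among the measured compounds shown here, no pair of measured compounds shows what an exchange at this aromatic carbon does, so the expectation rests on the value of compound 1 alone and must be wide. For compound 3 a moderate weakening is expected, the step of a 2.5-fold higher number from compound 1 to compound 3 (0.40 log units; beyond the scatter) being of a size just beyond the scatter, though a neutral outcome is well within the expected range. The estimate for compound 3 in this assay is 2500 nM, with a range from 500 nM to 12000 nM.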

Compound 3, half-maximal inhibitory concentration: 3500 nM
The estimate for compound 3 lay 1.4-fold (0.15 log units) below the measured number; the measured number falls inside the stated range.
By their numbers in this assay, from the lowest: compound 1; then compound 3; then compound 2.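

In this assay, among these compounds, the exchange of dichloromethyl for dimethylcarbamoyl on this aromatic carbon gives a 3.5-fold higher number from compound 1 to compound 3 (0.54 log units; beyond the scatter), the first step that isolates a single place, whereas the pair of compounds 1 and 2 differs at several places at once and could not be assigned to any one of them. The step is modest and inhibition remains measurable, so this position, on a six-membered aromatic ring of carbon only, accepts a change from a group with no hydrogen-bond acceptor and no double bond outside aromatic rings to one that has both, together with more heavy atoms, at a limited cost in the read-out.

Going by these compounds, with a single exchange on record, the size of the group and the presence of the hydrogen-bond acceptor cannot be separated, and it remains open how an amine, a carboxylic acid, a methyl ester or a longer chain would read at this aromatic carbon. Nothing measured on these compounds bears on what lies behind the step.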